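The compounds below may be only part of what the source reports. "The series", "measured", "known", "first", "only" and "open" are said of these compounds alone.

Measured so far in a functional assay on IMR-32 cells (Homo sapiens) for inhibition, read by sulforhodamine B assay, with a stated time of 48 h; on this read-out higher numbers stand for weaker inhibition of growth and lower numbers for stronger inhibition of growth:
- compound 1 `Nc1ccccc1C(=O)N/N=C/C1=C(Cl)c2ccccc2CCC1`: 51000 nM
- compound 2 `O=C(N/N=C/C1=C(Cl)c2ccccc2CCC1)c1cccnc1`: 150 nM
- compound 3 `Cc1cc2c(cc1C)C(Cl)=C(/C=N/NC(=O)c1ccccc1N)CCC2`: 36300 nM

Compound 1 and compound 3 carry different cores; the difference between the two cores is not broken down here. Their two values in this assay lie within the usual scatter of each other, so no order between them is claimed.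

Compound 2 differs from compound 1 by pyridin-3-yl in place of 2-aminophenyl on a carbonyl carbon, and this change gives a 340-fold lower number from compound 1 to compound 2 (2.53 log units; beyond the scatter).

Compound 4 `Cc1cc2c(cc1C)C(Cl)=C(/C=N/NC(=O)c1cccnc1)CCC2` has not yet been measured. It differs from compound 3 by pyridin-3-yl in place of 2-aminophenyl on a carbonyl carbon. Among the measured compounds shown here, the place is described in the same words for both pairs, so this is the same change as the one between compound 1 and compound 2, now made on the core of compound 3.

For the measured compounds named here, for compound 4 a step of about the earlier size is expected, a 300-fold lower number from compound 3 to compound 4 (2.48 log units; beyond the scatter), because the starting point of compound 3 at 36300 nM sits close to compound 1 at 51000 nM and the only measured instance of this change gave a 340-fold lower number from compound 1 to compound 2 (2.53 log units; beyond the scatter). Going by the values given here, only one instance supports this, so the range is kept wide.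

Compound 4 is therefore estimated at 120 nM in this assay, expected to fall between 30 nM and 600 nM.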

Compound 4, concentration for 50% growth inhibition: 8400 nM
Estimate against measurement, compound 4: 70-fold (1.85 log units) below; measured number above the stated range.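

In this assay, pyridin-3-yl in place of 2-aminophenyl on a carbonyl carbon again lowers the number, with a 4.3-fold lower number from compound 3 to compound 4 (0.64 log units; beyond the scatter), so the direction of the change is the same on both cores shown. The size of the step does not carry over from one core to the other: the same change on two cores in this assay, a 340-fold lower number (2.53 log units; beyond the scatter) from compound 1 to compound 2 and a 4.3-fold lower number (0.64 log units; beyond the scatter) from compound 3 to compound 4, 79-fold (1.90 log units) apart, beyond the scatter of two such steps With only these two pairs, the series shows that the core strongly influences how much this change delivers, but it does not show which part of the core difference is responsible, or what size of step a further core would give.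

The compounds shown leave open whether the core dependence is particular to pyridin-3-yl or also holds for other groups on the carbonyl carbon, such as an unsubstituted phenyl or a pyridin-4-yl. Also open, as far as these compounds go, is whether the 2-aminophenyl compounds or the pyridin-3-yl compounds are the ones that respond to the core, since a single pair of steps cannot separate the two.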